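The source may report more compounds than this note shows. Statements on the series, on what has been measured and on what is new or still open speak of the compounds shown alone.

Among the measured compounds shown here, in a functional assay on MDA-MB-231 cells (Homo sapiens) for cytotoxicity, read by MTT assay, with a stated time of 48 h (a lower number here means a stronger inhibitor, a higher number a weaker inhibitor), compound 2 (`CC(=O)Nc1cc(NC(=O)NCCCCC(c2ccc(F)cc2)c2ccc(F)cc2)ccc1Cl`) gives 9120 nM as the only actual number so far. Compound 1 (`Nc1ccc(NC(=O)NCCCCC(c2ccc(F)cc2)c2ccc(F)cc2)cc1`) gives > 20000 nM which is a limit of the assay. For the measured compounds named here, the only measured step (an at least 2.1-fold lower number from compound 1 to compound 2 (0.34 log units; beyond the scatter)) changed the group on the amide-type nitrogen, and the next change falls at that same place. Compound 3 (`Cc1ccc(NC(=O)NCCCCC(c2ccc(F)cc2)c2ccc(F)cc2)cc1C`) carries 3,4-dimethylphenyl in place of 3-acetamido-4-chlorophenyl (3,4-dimethylphenyl in place of 3-acetamido-4-chlorophenyl on an amide-type nitrogen) on that nitrogen. Going by the values given here, with only that modest step (an at least 2.1-fold lower number from compound 1 to compound 2 (0.34 log units; beyond the scatter)) as a guide, the expected change (a 1.1-fold higher number from compound 2 to compound 3 (0.04 log units; within the scatter)) is small and is not expected to exceed the scatter. Compound 3 is estimated at 10000 nM with an expected range from 4000 nM to 20000 nM in this assay for now.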

Compound 3, half-maximal inhibitory concentration: > 20000 nM
Compound 3: a limit, no number; the forecaster's own chance of this, stated with the estimate: 25%; middle value at least 2.0-fold (0.30 log units) from the limit.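

Putting 3,4-dimethylphenyl in place of 3-acetamido-4-chlorophenyl on the amide-type nitrogen gives an at least 2.1-fold higher number from compound 2 to compound 3 (0.34 log units; beyond the scatter), so this position does not treat every substituted phenyl group alike. The entering group has 0 hydrogen-bond donors and 0 hydrogen-bond acceptors where the leaving group has 1 of each, but the swap changes several atoms at once and singles out no one feature. The step between compound 1 and compound 3 cannot be read, as both compounds stand at a limit: the limit of > 20000 nM in this assay, at which 2 of the 3 values shown sit.

On these data alone, whether the acetamido group or the chlorine matters more in compound 2 stays open. So does what a sulfonamide at that place would give.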